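A few compounds are considered here, and "the series" means these few. Any claim that something is new, unique, unknown or untested is made for them only; others in the source may bear on it.

Of the compounds shown here, three have so far been measured in an assay on isolated protein for inhibition of protein deacetylase HDAC6 (Homo sapiens), read by fluorescence, with a stated time of 1 h, tested at 100 nM; a lower number here means less inhibition, a higher number more inhibition at the concentration tested (going by the name of the read-out). Compound 1 `O=C(/C=C/c1ccc(OCc2nc(C3CCN(Cc4ccccc4F)CC3)no2)cc1)NO` gives 68%, compound 2 `O=C(NO)c1ccc(OCc2nc(C3CCN(Cc4ccccc4)CC3)no2)cc1` gives 66%, and compound 3 `CN(Cc1nc(C2CCN(Cc3ccccc3)CC2)no1)c1ncc(/C=C/C(=O)NO)cn1` gives 55%. Compound 3 stands lowest of the three: its nearest neighbour on the numbers is compound 2, whose value lies higher by a margin beyond the scatter, and compound 1 lies higher still, again beyond the scatter. Going by the values given here, no two measured compounds differ in a single place, so no step size is known from within the set itself.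

Compound 4 `Cc1ccc(CN2CCC(c3noc(CN(C)c4ncc(/C=C/C(=O)NO)cn4)n3)CC2)cc1` is the next candidate for this assay. It differs from compound 3 in one place: methyl in place of hydrogen on an aromatic carbon. The change is a single carbon added on the benzyl group, with nothing in the measured set to anchor its effect. The working expectation is therefore a step of no change at the digits printed from compound 3 to compound 4 (within the scatter) that stays within the scatter, in no set direction. Compound 4 is estimated at 55%, with a range from 40% to 70%.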

Compound 4, a percentage reported as inhibition, at one concentration (the size of the read-out at that concentration, not a potency): 60%
Beside the measured number, compound 4's estimate is 5 percentage points below it; low and high end bracket the measured number.
By their numbers in this assay, from the lowest: compounds 3, 4, 2 and 1 (each within the scatter of the next, the first and the last beyond it).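

The series now has its first step in a single place: in this assay, methyl in place of hydrogen on the aromatic carbon para to a large group gives a number 5 percentage points higher from compound 3 to compound 4 (within the scatter) for this change. Going from benzyl to 4-methylbenzyl therefore leaves the inhibition read-out without a shift that can be told from the scatter, so this position accepts the added carbon without a clear loss or gain. No supporting measurement bears on why the step has this size.

On these data alone, whether a methoxy group, a chlorine atom or a carboxylic acid at this position would move the number stays open. Also open, as far as these compounds go, is whether the same change carries over to the core of compound 2, which holds the same benzyl group.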